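The source may report more compounds than this note shows. Statements on the series, on what has been measured and on what is new or still open speak of the compounds shown alone.

Working notes on the series. Compound 1 `COc1ccc(Oc2ccccc2-c2ccsc2S(=O)(=O)N2CCN(C(=O)Nc3ccc([N+](=O)[O-])cc3)CC2)cc1OC` is the reference point. In a functional assay on HeLa cells (Homo sapiens) for inhibition, read by CCK-8 assay, with a stated time of 48 h (a lower number here means a stronger inhibitor, a higher number a weaker inhibitor), compound 1 gives > 50000 nM, which is a limit of the assay and not a number. Compound 2 `COc1ccc(Oc2ccc([N+](=O)[O-])cc2-c2ccsc2S(=O)(=O)N2CCN(C(=O)Nc3ccc([N+](=O)[O-])cc3)CC2)cc1OC` carries a nitro in place of hydrogen on an aromatic carbon of the core of compound 1. In this assay compound 2 gives > 50000 nM, again a limit. The step that the two limits leave unreadable from compound 1 to compound 2 is therefore not readable. Compound 3 `O=C(NCCNS(=O)(=O)c1ccc(-c2ccccc2OCc2ccccc2)s1)Nc1cc(Cl)cc(Cl)c1` has no single-point relation to compound 1. In this assay compound 3 gives > 20000 nM, also a limit. Across the three measured compounds, the limit of > 50000 nM in this assay, at which 2 of the 3 values shown sit, and the limit of > 20000 nM in this assay, at which 1 of the 3 values shown sits, are all that is known, so compound 1 stands among limits only and no measured value is a number.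

Compound 4 `COc1ccc(Oc2ccccc2-c2ccsc2S(=O)(=O)N2CCN(C(=O)Nc3ccc(F)cc3)CC2)cc1OC` differs from compound 1 by fluoro in place of nitro on an aromatic carbon. Within the data shown here, no measured step touches this change; the only measured step, a step that the two limits leave unreadable from compound 1 to compound 2, concerns a different position and is itself unreadable. With every shown value a limit, there is no ground to expect a readable step, and the expected outcome is that compound 4 again reaches only a limit, so a step that the limit leaves unreadable from compound 1 to compound 4 is expected to be nil or unreadable. Compound 4 is estimated at 60000 nM, with a range of 15000 nM to 250000 nM.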

Compound 4, half-maximal inhibitory concentration: > 20000 nM
Compound 4: only a limit was reported; the forecaster's own chance of this, stated with the estimate: 80%; the middle value does not contradict the limit.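

In this assay compound 4 gives > 20000 nM, a limit of the assay and not a number. Compound 1 also stands at a limit, so no step can be read between compound 1 and compound 4 for fluoro in place of nitro. The compounds shown leave open whether any change to the shared core gives a numerical value in this assay.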